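The source may report more compounds than this note shows. Statements on the series, on what has been measured and on what is new or still open speak of the compounds shown alone.

In an ADME assay on MDBK cells (Bos taurus) for cytotoxicity, read by MTT assay (a higher number here means that more compound is tolerated, a lower number that less compound is tolerated), compound 1 (`CCCC1CCCCC1OCCCCCCN1C[C@H](O)[C@@H](O)[C@H](O)[C@H]1CO`) gives 150000 nM. Compound 2 (`CCC1CCC(OCCCCCCN2C[C@H](O)[C@@H](O)[C@H](O)[C@H]2CO)CC1`) gives > 500000 nM, which is a limit of the assay and not a number. Compound 3 (`CC1CCC(OCCCCCCN2C[C@H](O)[C@@H](O)[C@H](O)[C@H]2CO)CC1C`) differs from compound 2 in one place: a group of 8 heavy atoms (8 carbon; one six-membered non-aromatic ring of carbon only) in place of a group of 8 heavy atoms (8 carbon; one six-membered non-aromatic ring of carbon only), on an oxygen on a saturated carbon. The two have the same atoms, joined differently. Going by the values given here, the only measured step, an at least 3.3-fold higher number from compound 1 to compound 2 (0.52 log units; beyond the scatter), involved a group at this same place, so such a change can shift the number. Here no step beyond the scatter is expected, and the estimate is an at least 1.1-fold lower number from compound 2 to compound 3 (0.07 log units; that floor lies within the scatter). For compound 3 the expected value is 420000 nM, with an estimated range of 170000 nM to 1000000 nM.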

Compound 3, half-maximal cytotoxic concentration: > 500000 nM
Compound 3: no number, only a limit; the forecaster's own chance of this, stated with the estimate: 50%; middle value at least 1.1-fold (0.07 log units) from the limit.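

Compound 3 gives > 500000 nM, which is a limit of the assay and not a number. Rearranging the same atoms of the 4-ethylcyclohexyl group therefore gives a second group at this place that reaches the limit, and the new compound also shows an at least 3.3-fold higher number from compound 1 to compound 3 (0.52 log units; beyond the scatter). The step between compound 2 and compound 3 cannot be read, because both sit at the same limit: the limit of > 500000 nM in this assay, at which 2 of the 3 values shown sit.

Still open, as far as these compounds go, is how far either compound lies beyond that limit, and whether an amine or a carboxylic acid on this ring would bring the number back within range.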